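Propyl for Isopropyl on the Aryl Ether of Compound 1

A few compounds are considered here, and "the series" means these few. Any claim that something is new, unique, unknown or untested is made for them only; others in the source may bear on it.

Measured compounds:
compound 1 `Cc1cc(OC(C)C)cc(C)c1-c1cccc(COc2ccc(OCC(=O)O)c(F)c2)c1`: "not determined" (no result reported)
compound 2 `Cc1cc(OCCCS(C)(=O)=O)ccc1-c1cccc(COc2ccc(OCC(=O)O)c(F)c2)c1`: 1.63

Compound 1 `Cc1cc(OC(C)C)cc(C)c1-c1cccc(COc2ccc(OCC(=O)O)c(F)c2)c1` was run in a physicochemical assay for lipophilicity, using the shake flask method, in phosphate buffer, measured as octanol-water partition, with a stated time of 24 h, at pH 7.4, tested at 100 uM (a higher number here means a more lipophilic compound, a lower number a more polar compound), but returned "not determined" (no result reported), so it stands at no single number. Compound 2 `Cc1cc(OCCCS(C)(=O)=O)ccc1-c1cccc(COc2ccc(OCC(=O)O)c(F)c2)c1` gives 1.63 in this assay; it differs from compound 1 at more than one place, so its value shows only where one relative of the shared core lies.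

Compound 3 `CCCOc1cc(C)c(-c2cccc(COc3ccc(OCC(=O)O)c(F)c3)c2)c(C)c1` has not yet been measured. Its difference from compound 1 is propyl in place of isopropyl on an oxygen on an aromatic ring. The two compounds hold the same atoms joined differently, and the step from compound 1 to compound 3 in this assay is expected to be small, likely within the usual scatter, with no direction that can be stated with confidence.

Compound 3 is expected to give about 3.5 in this assay, with a range from 2.7 to 4.3.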

Compound 3, distribution coefficient: 3.64
The estimate for compound 3 lay 0.14 log units below the measured number; low and high end bracket the measured number.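

No step can be read between compound 1 and compound 3: in this assay compound 1 gives "not determined" (no result reported) and compound 3 gives 3.64 in the same test. The compounds shown leave open how far propyl in place of isopropyl moves this read-out on the shared core. No evidence at hand bears on the result.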